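Boron Group Opened and Ring-Closed on a Shared Core

The compounds below may be only part of what the source reports. "The series", "measured", "known", "first", "only" and "open" are said of these compounds alone.

Compound 3 `OB(O)c1ccc2ncnc(Nc3cccc(Cl)c3)c2c1` is one of three measured compounds that share a core. In an assay on isolated protein for inhibition of vascular endothelial growth factor receptor 1 (Homo sapiens), read by ELISA, with a stated time of 20 min (a lower number here means a stronger inhibitor, a higher number a weaker inhibitor), compound 3 gives > 1000 nM, which is a limit of the assay rather than a number. Compound 1 `OB(O)c1ccc2ncnc(Nc3ccc(F)c(Cl)c3)c2c1` differs from compound 3 by a fluoro on an aromatic carbon, and in this assay compound 1 gives > 1000 nM, again a limit. Compound 2 `COc1cc2ncnc(Nc3cccc(Cl)c3)c2cc1B1OC(C)(C)C(C)(C)O1` gives > 1000 nM in this assay, also a limit. Among the compounds with values here, the picture is therefore (the limit of > 1000 nM in this assay, at which 3 of the 3 values shown sit), and the only single-point step, a step that the two limits leave unreadable from compound 1 to compound 3, cannot be sized.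

Compound 4 `CC1(C)OB(c2ccc3ncnc(Nc4cccc(Cl)c4)c3c2)OC1(C)C` differs from compound 3 by a group of 9 heavy atoms (6 carbon, 1 boron, 2 oxygen; one five-membered non-aromatic ring with 3 hetero atoms) in place of a group of 3 heavy atoms (1 boron, 2 oxygen; no ring), on an aromatic carbon. Within the data shown here, no measured step covers exactly this change; compound 2, which carries the same entering group on a core with one further substituent, sits at the limit just as compound 3 does, so neither direction nor size can be read. The step from compound 3 to compound 4 is expected to be a step that the limit leaves unreadable from compound 3 to compound 4, with nothing to suggest a move beyond the scatter. Compound 4 is thus estimated at 3000 nM, within 800 nM to 20000 nM, most likely reported once more only as a limit.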

Compound 4, half-maximal inhibitory concentration: > 1000 nM
Compound 4 ended at the assay's limit; the forecaster's own chance of this, stated with the estimate: 85%; the middle value does not contradict the limit.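

Compound 4, like compound 2 and compound 3, stands only at a limit in this assay, so no new step can be read from these compounds: the limit of > 1000 nM in this assay, at which 4 of the 4 values shown sit.

The compounds shown leave open how strongly any of them inhibits this protein, and whether the ring-closed boron group differs from the open one.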